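Replacing the 1-methyl-1H-indol-3-yl group of compound 2

The compounds below may be only part of what the source reports. "The series", "measured", "known", "first", "only" and "open" are said of these compounds alone.

Measured so far in a functional assay on A549 cells (Homo sapiens) for inhibition, read by CCK-8 assay, with a stated time of 48 h; a higher number here means a weaker inhibitor, a lower number a stronger inhibitor:
Compound 1 `COc1cc(-c2ccnc3cc(-c4ccc(F)cc4)nn23)cc(OC)c1OC`: 3800 nM
Compound 2 `COc1cc(-c2ccnc3cc(-c4cn(C)c5ccccc45)nn23)cc(OC)c1OC`: 1340 nM

Of these two, compound 2 holds the lower number, at 1340 nM, and so is the stronger inhibitor. Compound 3 `COc1cc(-c2ccnc3cc(-c4ccc(N(C)C)cc4)nn23)cc(OC)c1OC` is the next to be measured. It carries 4-(dimethylamino)phenyl in place of 1-methyl-1H-indol-3-yl on an aromatic carbon. Among the measured compounds shown here, only one measured step bears on this change: a 2.8-fold lower number from compound 1 to compound 2 (0.45 log units; beyond the scatter), a modest step that brought in the same 1-methyl-1H-indol-3-yl group in place of 4-fluorophenyl. Compound 3 again has a substituted phenyl group, as does compound 1 at 3800 nM, so part of that gain is expected to be lost in this assay. With a single step as a guide, this expectation is loose. The expected change is a 1.7-fold higher number from compound 2 to compound 3 (0.23 log units; within the scatter). For compound 3 the estimated value is 2300 nM, with an expected range of 800 nM to 6500 nM.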

Compound 3, half-maximal inhibitory concentration: 1100 nM
Beside the measured number, compound 3's estimate is 2.1-fold (0.32 log units) above it; measured number inside the range.
By their numbers in this assay, from the lowest: compounds 3 and 2 (each within the scatter of the next); then compound 1.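

In this assay, a 1.2-fold lower number from compound 2 to compound 3 (0.09 log units; within the scatter) places the two compounds within the scatter of each other, so at this aromatic carbon 4-(dimethylamino)phenyl cannot be told apart from 1-methyl-1H-indol-3-yl. The earlier pair had tied the better number to the arrival of 1-methyl-1H-indol-3-yl, but a 3.5-fold lower number from compound 1 to compound 3 (0.54 log units; beyond the scatter) shows that a step of similar size is reached with a single six-membered aromatic ring, by dimethylamino in place of fluoro. No measured evidence here bears on why these groups give such numbers. The compounds shown leave open whether a morpholine, a methoxy group or a primary amine in place of dimethylamino would keep this number. They also leave open whether a pyridine ring in place of the phenyl ring would do so.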